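Ethoxy to 2-hydroxyethoxy on the shared core

The source may report more compounds than this note shows. Statements on the series, on what has been measured and on what is new or still open speak of the compounds shown alone.

In an ADME assay on microsomes from liver (Homo sapiens) for metabolic stability, with a stated time of 30 min (a lower number here means that less of the compound is left, a higher number that more of the compound is left), compound 1 `COc1nc2c(cc1Cc1cccc(Cl)c1F)c(=O)c(C(=O)O)cn2[C@H](CO)C(C)(C)C` gives 82% and compound 2 `CCOc1nc2c(cc1Cc1cccc(Cl)c1F)c(=O)c(C(=O)O)cn2[C@H](CO)C(C)(C)C` gives 84% as its reading. These two values lie within the scatter of each other, so the assay does not separate the two compounds. The next structure is compound 3 `CC(C)(C)[C@@H](CO)n1cc(C(=O)O)c(=O)c2cc(Cc3cccc(Cl)c3F)c(OCCO)nc21` and its difference from compound 2 is hydroxy in place of hydrogen on a saturated chain carbon, two bonds along the chain from an oxygen on an aromatic ring on the same chain. In words, this places hydroxy in place of hydrogen on a saturated chain carbon, two bonds along the chain from an oxygen on an aromatic ring, turning ethoxy into 2-hydroxyethoxy. Among the measured compounds shown here, the only measured step on this chain is a number 2 percentage points higher from compound 1 to compound 2 (within the scatter) and it introduces a methyl, not a hydroxy. For the measured compounds named here, no measured compound carries a hydroxy on this chain, so that step is only a weak guide. No shift beyond the scatter is expected, although the uncertainty is wide. The estimated change is a number 4 percentage points lower from compound 2 to compound 3 (within the scatter) in this assay. For compound 3 the expected value is 80% with an estimated range from 65% to 93% in this assay for now.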

Compound 3, percent of the compound remaining: 45%
Compound 3: middle estimate off by 35 percentage points, on the high side, and the stated range ends above it.
By their numbers in this assay, from the lowest: compound 3; then compounds 1 and 2 (each within the scatter of the next).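

Adding hydroxy to the ethoxy chain gives a number 39 percentage points lower from compound 2 to compound 3 (beyond the scatter) in this assay, whereas going from methoxy to ethoxy gave a number 2 percentage points higher from compound 1 to compound 2 (within the scatter), so the earlier pair had given no sign that this chain could move the read-out at all. The comparison with the methoxy compound points the same way, with hydroxymethyl in place of hydrogen on the saturated chain carbon bound to the oxygen on the aromatic ring giving a number 37 percentage points lower from compound 1 to compound 3 (beyond the scatter), so the drop does not depend on which of the two earlier compounds serves as the reference. This position therefore responds strongly to which group enters: the added methyl leaves the number within the scatter, while the added hydroxy takes it well beyond.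

The compounds shown offer no information that bears on why the number falls. On these data alone, it remains open whether the drop belongs to the hydroxy alone or would also follow a methyl ether, an amine or a carboxylic acid at the end of the ethoxy chain, and whether a longer chain carrying the same hydroxy would give a similar reading.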